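The source may hold more compounds than are shown below. What is called first, only, known or untested is meant among the compounds shown, and "the series" means these compounds.

Compound 3 `C/C(=N\NC(N)=O)c1ccc2c(c1)nc(-c1ccccc1)n2C1CCCCC1` is one of four closely related compounds built on a shared core. Compound 1 `C/C(=N\NC(N)=O)c1ccc2[nH]c(-c3ccccc3)nc2c1` carries the same semicarbazone arm but lacks the cyclohexyl group on a ring nitrogen; compound 2 `CC(=O)c1ccc2c(c1)nc(-c1ccccc1)n2C1CCCCC1` keeps the cyclohexyl group and bears an acetyl group instead of the semicarbazone. In an ADME assay on MT4 cells (Homo sapiens) for cytotoxicity, read by MTT assay, with a stated time of 96 h (on this read-out lower numbers stand for higher toxicity in this test and higher numbers for lower toxicity in this test), compound 2 gives 37000 nM. In this assay compound 1 gives "not determined" (no result reported), and in this assay compound 3 gives "not determined" (no result reported), so compound 3 stands without a number of its own, and the only measured point in the series is compound 2.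

Compound 4 `COc1ccc(-c2nc3cc(/C(C)=N/NC(N)=O)ccc3n2C2CCCCC2)c(OC)c1` differs from compound 3 in one place: 2,4-dimethoxyphenyl in place of phenyl on an aromatic carbon

Going by the values given here, no step between measured compounds is available here, so the size of the change from compound 3 to compound 4 in this assay cannot be read from the data. Given that compound 2 gives 37000 nM and that these compounds show little cytotoxicity in this assay, compound 4 is expected to fall in a similar range, with a difference no larger than the usual scatter. Compound 4 is estimated to give 40000 nM in this assay, expected to lie between 12000 nM and 150000 nM.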

Compound 4, half-maximal cytotoxic concentration: 23000 nM
The estimate for compound 4 lay 1.7-fold (0.24 log units) above the measured number; measured number inside the range.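

In this assay, going by these compounds alone, compound 3 gives "not determined" (no result reported), so no step from it to compound 4 can be read from this result. No measured evidence bears on the value of compound 4. The compounds shown leave open whether 2,4-dimethoxyphenyl in place of phenyl changes the half-maximal cytotoxic concentration at all.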